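Two Esters and Two Alcohols on a Bridged Core

A few compounds are considered here, and "the series" means these few. Any claim that something is new, unique, unknown or untested is made for them only; others in the source may bear on it.

Measured compounds in an ADME assay on L6 cells (Rattus norvegicus) for cytotoxicity, with a stated time of 72 h; on this read-out higher numbers stand for weaker inhibition and lower numbers for stronger inhibition:
compound 1 `O=C(CN1CCCCC1)OC1CC2(N3CCCC3)CC(c3ccccc3)C1C(c1ccccc1)C2`: 14200 nM
compound 2 `OC1CC2(N3CCCC3)CC(c3ccccc3)C1C(c1ccccc1)C2`: 26800 nM
compound 3 `CN(C)C12CC(OC(=O)CN3CCCCC3)C(C(c3ccccc3)C1)C(c1ccccc1)C2`: 29300 nM

Compound 4 `CN(C)C12CC(O)C(C(c3ccccc3)C1)C(c1ccccc1)C2` has not yet been measured in this assay. Compound 1 and compound 3 share the ester, and their cores differ as dimethylamino in place of pyrrolidin-1-yl on a saturated ring carbon, a change that in this assay gave a 2.1-fold higher number from compound 1 to compound 3 (0.31 log units; beyond the scatter). The values of compound 2 and compound 3 lie within the scatter of one another, so no order between them can be claimed.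

From compound 1 to compound 2 the change is hydrogen in place of ((piperidin-1-yl)methyl)carbonyl on an oxygen on a saturated carbon, and it gave a 1.9-fold higher number from compound 1 to compound 2 (0.28 log units; within the scatter). The same change, (hydrogen in place of ((piperidin-1-yl)methyl)carbonyl on an oxygen on a saturated carbon), carries compound 3 to compound 4. The two places are the same word for word, so this is the same change on a different core. On that single earlier step compound 4 is expected to give a number somewhat higher than compound 3, a step of about a 1.7-fold higher number from compound 3 to compound 4 (0.23 log units; within the scatter), because the step to compound 2 was a 1.9-fold higher number from compound 1 to compound 2 (0.28 log units; within the scatter). Resting on the value of compound 3, 29300 nM, compound 4 is estimated at 50000 nM, with a likely range from 25000 nM to 100000 nM.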

Compound 4, half-maximal inhibitory concentration: 133000 nM
Compound 4: middle estimate off by 2.7-fold (0.42 log units), on the low side; measured number above the stated range.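

In this assay, hydrogen in place of ((piperidin-1-yl)methyl)carbonyl on the oxygen gave a 4.5-fold higher number from compound 3 to compound 4 (0.66 log units; beyond the scatter), and this step cannot be told apart in size from the one seen on the core of compound 1: the same change on two cores in this assay, a 1.9-fold higher number (0.28 log units; within the scatter) from compound 1 to compound 2 and a 4.5-fold higher number (0.66 log units; beyond the scatter) from compound 3 to compound 4, 2.4-fold (0.38 log units) apart, within the scatter of two such steps

Dimethylamino in place of pyrrolidin-1-yl on a saturated ring carbon gave a 5.0-fold higher number from compound 2 to compound 4 (0.70 log units; beyond the scatter), and this step likewise cannot be told apart from its earlier counterpart on the ester pair: the same change on two cores in this assay, a 2.1-fold higher number (0.31 log units; beyond the scatter) from compound 1 to compound 3 and a 5.0-fold higher number (0.70 log units; beyond the scatter) from compound 2 to compound 4, 2.4-fold (0.38 log units) apart, within the scatter of two such steps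

Within these four compounds, then, each change can be carried from one core to the other without a measurable difference in step size, but this does not show that the two steps are equal, nor that either change would carry over to any other core.

The compounds shown leave open whether a morpholine or a primary amine in place of pyrrolidin-1-yl would follow the same course. They also leave open how an ester with a longer chain before the piperidine, or a simple acetate, would compare with the hydroxy compounds.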